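Swapping the Pyridyl Group for a Methyl Amide

This account rests on a few compounds, and the source may have more. Where it says the series, first, only, none or still open, it means among the compounds named here.

Measured compounds, all in an assay on isolated protein for inhibition of Fatty-acid amide hydrolase 1 (Rattus norvegicus); on this read-out lower numbers stand for stronger inhibition and higher numbers for weaker inhibition:
Compound 1 `O=C(CCCCCCc1ccccc1)c1nc(Br)co1` gives 3 nM.
Compound 2 `CC(=O)c1coc(C(=O)CCCCCCc2ccccc2)n1` gives 2 nM.
Compound 3 `O=C(CCCCCCc1ccccc1)c1nc(-c2ccncc2)co1` gives 1.6 nM.

Compound 3 shows the lowest number of the three, but its steps to the others, a 1.9-fold lower number from compound 1 to compound 3 (0.27 log units; within the scatter) and a 1.3-fold lower number from compound 2 to compound 3 (0.10 log units; within the scatter), both lie within the scatter, so no order among them can be claimed. Compound 4 `CNC(=O)c1coc(C(=O)CCCCCCc2ccccc2)n1` differs from compound 3 by methylcarbamoyl in place of pyridin-4-yl on an aromatic carbon. Every change made so far at that same ring carbon, including a 1.5-fold lower number from compound 1 to compound 2 (0.18 log units; within the scatter), has left the number within the scatter. The expected step from compound 3 to compound 4 is therefore a 1.9-fold higher number from compound 3 to compound 4 (0.27 log units; within the scatter), with no change beyond the scatter. Compound 4 is estimated at 3 nM, in a range from 1 nM to 10 nM.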

Compound 4, inhibition constant: 1.8 nM
Beside the measured number, compound 4's estimate is 1.7-fold (0.22 log units) above it; measured number inside the range.
By their numbers in this assay, from the lowest: compounds 3, 4, 2 and 1 (each within the scatter of the next).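

The position tolerates a new kind of group: methylcarbamoyl has no ring and carries a hydrogen-bond donor, yet in this assay its exchange for pyridin-4-yl stays within the scatter (a 1.1-fold higher number from compound 3 to compound 4 (0.05 log units; within the scatter)). Turning the acetyl into this amide, methylamino in place of methyl on a carbonyl carbon, also stays within it (a 1.1-fold lower number from compound 2 to compound 4 (0.05 log units; within the scatter)), as does the exchange for bromo (a 1.7-fold lower number from compound 1 to compound 4 (0.22 log units; within the scatter)). No measurement here gives a reason for this flat result.

From the compounds shown here alone, whether an amine, a carboxylic acid or a longer chain on this ring carbon would move the number beyond the scatter remains open.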